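Loss of the 4-methoxybenzyl group: compound 3 to compound 4

The source may hold more compounds than are shown below. What is called first, only, known or untested is meant among the compounds shown, and "the series" means these compounds.

Among the measured compounds shown here, in a functional assay on MDA-MB-231 cells (Homo sapiens) for antiproliferative activity, read by WST assay, with a stated time of 72 h (a higher number here means a weaker inhibitor, a lower number a stronger inhibitor), compound 3 `CCCCCCCC/N=c1\nc(N)c2ncn(Cc3ccc(OC)cc3)c2c(N)n1` gives 2550 nM, the second highest of the three numbers so far. Compound 2 `CCCCCCCCCC/N=c1\nc(N)c2ncn(Cc3ccccc3)c2c(N)n1` gives 2050 nM, within the scatter of compound 3, while compound 1 `Nc1n/c(=N\CCCCc2ccccc2)nc(N)c2c1ncn2Cc1ccccc1` gives 16700 nM. For the measured compounds named here, the only step between measured compounds, an 8.1-fold lower number from compound 1 to compound 2 (0.91 log units; beyond the scatter), concerns the saturated chain and not the ring nitrogen. Compound 4 `CCCCCCCC/N=c1\nc(N)c2nc[nH]c2c(N)n1` differs from compound 3 by hydrogen in place of 4-methoxybenzyl on an aromatic nitrogen. Going by the values given here, no measured step bears on this change, so its size in this assay cannot be read from the series. The step is expected to be a 2.4-fold higher number from compound 3 to compound 4 (0.37 log units; beyond the scatter), a modest drift toward a higher number with wide uncertainty. Compound 4 is therefore estimated at 6000 nM, with a range from 2000 nM to 20000 nM.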

Compound 4, half-maximal inhibitory concentration: "not active" (no number reported)
The entry for compound 4 holds no number; no gap can be computed for the estimate.
By their numbers in this assay, from the lowest: compounds 2 and 3 (each within the scatter of the next); then compound 1.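

Among the compounds shown here, compound 4 is reported as "not active" without a number, so no step from compound 3 to compound 4 can be read. No evidence on hand bears on this result. The compounds shown leave open how large the effect of losing the 4-methoxybenzyl group is.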